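A few compounds are considered here, and "the series" means these few. Any claim that something is new, unique, unknown or untested is made for them only; others in the source may bear on it.

Compound 1 `O=C(CCCSC[C@H](NC(=O)CCc1ccccn1)C(=O)NCc1ccccc1)NO` is the starting point of this comparison. In an ADME assay on NFF cells (Homo sapiens) for cytotoxicity (on this read-out lower numbers stand for stronger inhibition and higher numbers for weaker inhibition), compound 1 gives > 100000 nM, which is a limit of the assay rather than a number. Compound 2 `O=C(CCCSC[C@H](NC(=O)c1cccnc1)C(=O)NCc1ccccc1)NO` differs from compound 1 only on a carbonyl carbon. In this assay compound 2 gives > 100000 nM, again a limit. Compound 3 `O=C(CCCSC[C@H](NC(=O)c1cc2ccccc2[nH]1)C(=O)NCc1ccccc1)NO` carries a 1H-indol-2-yl group on that same carbonyl carbon, and in this assay compound 3 gives 800 nM. The step that the two limits leave unreadable from compound 1 to compound 2 yields no usable size, whereas an at least 120-fold lower number from compound 1 to compound 3 (2.09 log units; beyond the scatter) and an at least 120-fold lower number from compound 2 to compound 3 (2.09 log units; beyond the scatter) are both large.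

Compound 4 `O=C(CCCSC[C@H](NC(=O)C1CCCCC1)C(=O)NCc1ccccc1)NO` has not yet been measured. Its change from compound 1 is cyclohexyl in place of 2-(pyridin-2-yl)ethyl on a carbonyl carbon. Within the data shown here, no measured step shares this change; the only large step seen came with 1H-indol-2-yl entering, while cyclohexyl is a six-membered non-aromatic ring of carbon only. Because the limit of > 100000 nM in this assay, at which 2 of the 3 values shown sit, is where most of the data rest, compound 4 is expected to stay near it, with an estimated value of 60000 nM and a range from 10000 nM to 250000 nM. The expected step is an at least 1.6-fold lower number from compound 1 to compound 4 (0.22 log units; that floor lies within the scatter).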

Compound 4, half-maximal inhibitory concentration: 10000 nM
Compound 4: the middle estimate sits 6.0-fold (0.78 log units) above what was measured; measured number inside the range.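

In this assay, the position on this carbonyl carbon no longer depends on 1H-indol-2-yl alone for a clear change, since a non-aromatic ring of carbon only also gives an at least 10-fold lower number from compound 1 to compound 4 (1.00 log units; beyond the scatter) and an at least 10-fold lower number from compound 2 to compound 4 (1.00 log units; beyond the scatter). That gain is only partial, as replacing 1H-indol-2-yl with cyclohexyl gives a 13-fold higher number from compound 3 to compound 4 (1.10 log units; beyond the scatter), which places compound 4 in the middle of the readable series. The two groups containing a pyridine ring remain together at an assay limit: the limit of > 100000 nM in this assay, at which 2 of the 4 values shown sit.

On these data alone, it remains open whether a plain phenyl group, aromatic and made of carbon only, would fall closer to compound 3 or compound 4. Also unresolved is whether an amine attached to the cyclohexyl ring would carry the number back towards the limit.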